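The source may hold more compounds than are shown below. What is called first, only, known or untested is meant among the compounds shown, and "the series" means these compounds.

Measured so far in an ADME assay on microsomes from liver (Mus musculus) for metabolic stability, read by LC-MS, using NADPH, with a stated time of 10 min, tested at 10 uM; a higher number here means that the compound lasts longer, a lower number that the compound disappears faster:
Compound 1 `CC(C)(C)n1nc(Oc2cc(O)ccn2)c2c(N)ncnc21`: 0.617 h
Compound 2 `N#Cc1ccnc(Oc2nn([C@H]3C[C@@H](O)C3)c3ncnc(N)c23)c1`: > 2.41 h

Compound 2 reads > 2.41 h in this assay, and that reading is a limit of the assay, not a number. Compound 3 `CC(C)(C)n1nc(Oc2cc(C#N)ccn2)c2c(N)ncnc21` has not yet been measured. It differs from compound 2 by tert-butyl in place of 3-hydroxycyclobutyl on an aromatic nitrogen. Going by the values given here, no measured pair of compounds isolates this change, so the expectation rests on a single reference point: compound 1 also carries tert-butyl on that nitrogen, and compound 1 gives 0.617 h. On that basis, the expected step, an at least 2.1-fold lower number from compound 2 to compound 3 (0.34 log units; beyond the scatter), is a fall in half-life beyond the usual scatter, with its true size left open by the limit. For compound 3 the estimated half-life is 1.1 h, with an expected range from 0.45 h to 2.8 h.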

Compound 3, half-life: 0.767 h
For compound 3 the middle estimate is 1.4-fold (0.16 log units) above the measured one; the measured number falls inside the stated range.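

In this assay, putting tert-butyl in place of 3-hydroxycyclobutyl on the aromatic nitrogen now has a direct comparison, and it gives an at least 3.1-fold lower number from compound 2 to compound 3 (0.49 log units; beyond the scatter). The reading of compound 2, > 2.41 h, is a limit of the assay and not a number, so the true size of that step stays open: the limit of > 2.41 h in this assay, at which 1 of the 3 values shown sits.

Putting cyano in place of hydroxy on the aromatic carbon gives a 1.2-fold higher number from compound 1 to compound 3 (0.09 log units; within the scatter), so with tert-butyl on the nitrogen these two groups read alike.

The compounds shown do not tell whether the hydroxy or the four-membered ring of 3-hydroxycyclobutyl accounts for the difference, since a plain cyclobutyl, or a cyclobutyl bearing an amine in place of the hydroxy, is not among them. They also leave open whether cyano and hydroxy would still read alike with 3-hydroxycyclobutyl on the nitrogen.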